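Fluoropropoxy analogue of compound 1: expected binding

The compounds below may be only part of what the source reports. "The series", "measured", "known", "first", "only" and "open" are said of these compounds alone.

Measured compounds in an assay on HEK293 cells for displacement of a labelled ligand from Neuronal acetylcholine receptor; alpha3/beta4 (Homo sapiens), read by scintillation counting, with a stated time of 120 min; on this read-out higher numbers stand for weaker inhibition and lower numbers for stronger inhibition:
compound 1 `Fc1ccc(COc2cccc(-c3cn(C4CN5CCC4CC5)nn3)c2)cc1` gives 13.9 nM
compound 2 `Fc1ccc(COc2cccc(-c3cn([C@@H]4CN5CCC4CC5)nn3)c2)cc1` gives 7.17 nM
compound 3 `Fc1ccc(-c2cn([C@H]3CN4CCC3CC4)nn2)cc1` gives 1010 nM

Compound 1 stands second highest of the three numbers. Its nearest neighbour is compound 2, a 1.9-fold lower number from compound 1 to compound 2 (0.29 log units; within the scatter), a pair that differs only in that (the fact that one of compounds 1 and 2 is drawn with a defined configuration and the other without, at the place where they differ). For the measured compounds named here, compound 3 lies furthest away, with a much higher number; it lacks the whole (4-fluorobenzyl)oxy part of compound 1, and no single-place step connects the two.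

Compound 4 `FCCCOc1cccc(-c2cn(C3CN4CCC3CC4)nn2)c1` differs from compound 1 by 2-fluoroethyl in place of 4-fluorophenyl on a saturated chain carbon bound to an oxygen on an aromatic ring. Going by the values given here, no measured step touches this position, so the expectation rests on the gap between compounds 1 and 3 alone. Compound 4 is expected to give a somewhat higher number, a 4.3-fold higher number from compound 1 to compound 4 (0.64 log units; beyond the scatter). Compound 4 is estimated at 60 nM, within 15 nM to 300 nM.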

Compound 4, inhibition constant: 44.4 nM
Estimate against measurement, compound 4: 1.4-fold (0.13 log units) above; the measured number falls inside the stated range.
By their numbers in this assay, from the lowest: compounds 2 and 1 (each within the scatter of the next); then compound 4; then compound 3.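

The 4-fluorophenyl ring on this saturated chain carbon is not indispensable: 2-fluoroethyl, which has no ring, can replace it at a modest cost (a 3.2-fold higher number from compound 1 to compound 4 (0.50 log units; beyond the scatter)). The step lies beyond the scatter, so this position does respond to the change. Nothing in hand bears on why the number rises.

Still open, going by these compounds, is whether the fluorine contributes in either group, and how a longer chain or a terminal amine would compare. Also open, on these data alone, is how compound 4 behaves when drawn with a defined configuration.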